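This account rests on a few compounds, and the source may have more. Where it says the series, first, only, none or still open, it means among the compounds named here.

Compound 1 `N#Cc1cccc(-n2nnc(-c3ncc[nH]3)n2)c1`: 34 nM in an assay for binding affinity to metabotropic glutamate receptor 5 (Rattus norvegicus); a lower number here means a stronger inhibitor, a higher number a weaker inhibitor
Compound 2 `N#Cc1cccc(-n2nnc(-c3ccccn3)n2)c1`: 102 nM
Compound 3 `N#Cc1cccc(-n2nnc(-c3nccs3)n2)c1`: 183 nM

Compound 3 carries the highest of the three numbers, though the gap to compound 2 is within the scatter (a 1.8-fold higher number from compound 2 to compound 3 (0.25 log units; within the scatter)), while compound 1 stands well apart (a 5.4-fold higher number from compound 1 to compound 3 (0.73 log units; beyond the scatter)). Compound 4 `N#Cc1cccc(-n2nnc(-c3cscn3)n2)c1` differs from compound 3 only in that (1,3-thiazol-4-yl in place of 1,3-thiazol-2-yl on an aromatic carbon). Among the compounds with values here, no measured step moves a ring from one attachment point to another; the steps of a 3.0-fold higher number from compound 1 to compound 2 (0.48 log units; beyond the scatter) and a 5.4-fold higher number from compound 1 to compound 3 (0.73 log units; beyond the scatter) show that swapping one ring for another shifts this assay by a modest amount. A change of that size or smaller, in either direction, is expected, so the estimated step of a 1.4-fold higher number from compound 3 to compound 4 (0.14 log units; within the scatter) is small. Compound 4 is estimated at 250 nM, within 80 nM to 800 nM.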

Compound 4, inhibition constant: 157 nM
Estimate against measurement, compound 4: 1.6-fold (0.20 log units) above; the range from low to high includes it.
By their numbers in this assay, from the lowest: compound 1; then compounds 2, 4 and 3 (each within the scatter of the next).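

With a 1.2-fold lower number from compound 3 to compound 4 (0.07 log units; within the scatter) the two attachment points of the thiazole cannot be told apart in this assay at this carbon of the shared core. With a 1.5-fold higher number from compound 2 to compound 4 (0.19 log units; within the scatter) the 1,3-thiazol-4-yl group also cannot be told apart from pyridin-2-yl, while a 4.6-fold higher number from compound 1 to compound 4 (0.66 log units; beyond the scatter) leaves compound 1 with the lowest number of the four, its steps to all the others lying beyond the scatter. Nothing available here explains this pattern. On these data alone, what sets the 1H-imidazol-2-yl group apart stays open, as does how an amine, a carboxylic acid or a piperidine ring on this carbon would read.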